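The compounds below may be only part of what the source reports. "The series", "measured", "known", "first", "only" and "open" are said of these compounds alone.

Values measured so far in an in vivo ADME assay on the whole organism (strain Sprague-Dawley) for pharmacokinetics, with Rattus norvegicus as the target, at a dose of 4 mg/kg by the oral route (on this read-out lower numbers stand for lower oral bioavailability and higher numbers for higher oral bioavailability), are these:
- compound 1 `O=C(NC[C@@H](O)C(=O)O)c1ccc(CN(C(=O)Nc2cccc(Br)c2)c2ccc(C3CCCCC3)cc2)cc1` gives 21%
- compound 2 `O=C(NC[C@@H](O)C(=O)O)c1ccc(CN(C(=O)Nc2cc(Br)cc(C(F)(F)F)c2)c2ccc(C3=CCCCC3)cc2)cc1` gives 14%

Compound 2 gives 14% in this assay and so lies within the usual scatter of compound 1, whose value is 21% on the same read-out. These two numbers cannot be ranked.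

Compound 3 `COc1cc(NC(=O)N(Cc2ccc(C(=O)NC[C@@H](O)C(=O)O)cc2)c2ccc(C3=CCCCC3)cc2)cc(C(F)(F)F)c1` has not been measured yet. It keeps the rest of compound 2 and exchanges one group (methoxy in place of bromo on an aromatic carbon), with methoxy in place of bromo on an aromatic carbon, meta to a trifluoromethyl group.

Among the compounds with values here, no two measured compounds differ in one place only, so the data hold no direct precedent for this exchange. Compound 2 at 14% is the closest measured relative, so the expectation stays near that value, with no step beyond the scatter in either direction. The estimated step is a number 1 percentage points higher from compound 2 to compound 3 (within the scatter) and is expected to remain within the scatter. For compound 3 the expected value is 15%, with an estimated range from 5% to 30%.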

Compound 3, oral bioavailability: 7%
Compound 3: the middle estimate sits 8 percentage points above what was measured; the measured number falls inside the stated range.
By their numbers in this assay, from the lowest: compounds 3, 2 and 1 (each within the scatter of the next, the first and the last beyond it).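

In this assay, within the data shown here, the exchange of bromo for methoxy gives the first comparison in this set between two compounds that differ in one place only, and the step reads a number 7 percentage points lower from compound 2 to compound 3 (within the scatter). At this position, meta to a trifluoromethyl group, swapping a single bromine atom for a methoxy group, with two heavy atoms and one hydrogen-bond acceptor, therefore leaves oral bioavailability indistinguishable from that of the bromo compound on this read-out. The data shown hold no separate measurement that could explain this result.

From the compounds shown here alone, it remains open whether a nitrile, an amine or a longer chain such as ethoxy at this position would give a step beyond the usual scatter in this assay. Going by these compounds, it is also open whether the same exchange of bromo for methoxy would read alike on the core of compound 1, which carries no trifluoromethyl group on that ring.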